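Compound 3: 2-chloropyridin-4-yl in place of pyridin-3-yl

The source may hold more compounds than are shown below. What is called first, only, known or untested is meant among the compounds shown, and "the series" means these compounds.

Among the measured compounds shown here, in a physicochemical assay for lipophilicity, read by LC-MS, in phosphate buffer, measured as octanol-water partition, at pH 7.4, tested at 66.7 uM (on this read-out higher numbers stand for higher lipophilicity and lower numbers for lower lipophilicity), compound 2 (`CN1CCN(c2ccc(Nc3nccc(-c4cccnc4)n3)cc2C(F)(F)F)CC1`) gives 3.53 as the only true number so far. Compound 1 (`CN1CCN(c2ccc(Nc3nccc(-c4ccc5ccccc5c4)n3)cc2C(F)(F)F)CC1`) gives > 5.7 here, which is a limit of the assay and not a number. For the measured compounds named here, the single measured step at this aromatic carbon, pyridin-3-yl in place of naphthalen-2-yl, reads a number at least 2.17 log units lower from compound 1 to compound 2 (beyond the scatter) and is bounded on one side only.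

The next change leads to compound 3 (`CN1CCN(c2ccc(Nc3nccc(-c4ccnc(Cl)c4)n3)cc2C(F)(F)F)CC1`) and is 2-chloropyridin-4-yl in place of pyridin-3-yl on an aromatic carbon at that same carbon. One six-membered aromatic ring with 1 hetero atom leaves and another enters, so chlorine is the added atom. The large measured step replaced naphthalen-2-yl, so it bears only on direction and sets a loose upper bound on size. A moderate rise beyond the scatter is therefore expected, well short of that step. The expected change is a number 0.67 log units higher from compound 2 to compound 3 (beyond the scatter) in this assay on this estimate. Compound 3 is expected at 4.2 (estimated range 3.7 to 4.7) when measured.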

Compound 3, distribution coefficient: 4.3
For compound 3 the middle estimate is 0.10 log units below the measured one; measured number inside the range.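

In this assay this aromatic carbon now has its first step between two true numbers: a number 0.77 log units higher from compound 2 to compound 3 (beyond the scatter). Both rings are six-membered aromatic rings with 1 hetero atom, yet the step combines the added chlorine with a move from a pyridin-3-yl to a pyridin-4-yl attachment, and the two cannot be separated on these compounds. Compound 3 also gives a second comparison with naphthalen-2-yl, a number at least 1.40 log units lower from compound 1 to compound 3 (beyond the scatter), and the value of compound 1 in that comparison is a limit of the assay and not a number, so the step is bounded on one side only: the limit of > 5.7 in this assay, at which 1 of the 3 values shown sits.

From the compounds shown here alone, how much of the step from pyridin-3-yl belongs to the chlorine and how much to the change of attachment stays open, and plain pyridin-4-yl at the same carbon would divide the two. Also open, going by these compounds, is how the read-out responds to other groups in place of that chlorine on the pyridine ring, such as fluorine, methoxy, an amine or a carboxylic acid.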